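The source may report more compounds than this note shows. Statements on the series, on what has been measured and on what is new or still open speak of the compounds shown alone.

Among the compounds with values here, compound 1 `COc1cc(-c2cc(/C=C/C(=O)c3ccc(N)cc3)[nH]n2)cc(OC)c1OC` is one of two compounds measured in a functional assay on M14 cells (Homo sapiens) for inhibition, read by sulforhodamine B assay, with a stated time of 48 h; a lower number here means a stronger inhibitor of growth, a higher number a weaker inhibitor of growth; in this assay compound 1 gives 3860 nM, the lower of the two numbers. Compound 2 `COc1ccc(-c2cc(/C=C/C(=O)c3ccc(N)cc3)[nH]n2)cc1OC` shares its core and gives 5110 nM. Within the data shown here, the only measured step, a 1.3-fold higher number from compound 1 to compound 2 (0.12 log units; within the scatter), concerns hydrogen in place of methoxy on an aromatic carbon and stays within the scatter, so the two values cannot be ordered.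

Compound 3 `COc1cc(-c2cc(/C=C/C(=O)c3ccc(F)c(F)c3)[nH]n2)cc(OC)c1OC` differs from compound 1 at a different place: 3,4-difluorophenyl in place of 4-aminophenyl on a carbonyl carbon. Among the measured compounds shown here, no measured step touches the group on the carbonyl carbon, and the step from compound 1 to compound 2, which changes another ring, says nothing about this exchange. The expectation for compound 3 therefore rests on the value of compound 1 alone, 3860 nM, with a wide range and no clear direction. Compound 3 is estimated at 5000 nM, within 1500 nM to 16000 nM, which means an expected step of a 1.3-fold higher number from compound 1 to compound 3 (0.11 log units; within the scatter).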

Compound 3, concentration for total growth inhibition: 11900 nM
Beside the measured number, compound 3's estimate is 2.4-fold (0.38 log units) below it; measured number inside the range.
By their numbers in this assay, from the lowest: compounds 1 and 2 (each within the scatter of the next); then compound 3.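

In this assay, 3,4-difluorophenyl in place of 4-aminophenyl on a carbonyl carbon gives a 3.1-fold higher number from compound 1 to compound 3 (0.49 log units; beyond the scatter). Within the data shown here, this is the first step in the set that lies beyond the scatter, so the group on the carbonyl carbon can shift the number in a way the methoxy exchange on the other ring did not show. Because both changes fall in one exchange, the result cannot separate the loss of the amino group from the arrival of the two fluorines, and nothing available accounts for the weaker growth inhibition of compound 3.

On these data alone, it remains open whether a plain phenyl, a 4-fluorophenyl or a 4-hydroxyphenyl group on the carbonyl carbon would give a number closer to that of compound 1 or that of compound 3. As far as these compounds go, it is also open whether the same exchange would give a step of similar size starting from compound 2.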